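A few compounds are considered here, and "the series" means these few. Any claim that something is new, unique, unknown or untested is made for them only; others in the source may bear on it.

In a functional assay on MCF7 cells (Homo sapiens) for antiproliferative activity, read by MTT assay, with a stated time of 48 h (a lower number here means a stronger inhibitor, a higher number a weaker inhibitor), compound 1 (`COc1ccc(C(=O)c2ccc(OC)c3c2OC(C)(C)C=C3)c(NC(=O)CN)c1`) gives 410 nM, compound 2 (`C=C(c1ccc2c(c1)C=CC(C)(C)O2)c1ccc(OC)cc1NC(=O)CN(C)C`) gives 940 nM and compound 3 (`C=C(c1cc(OC)c(OC)c(OC)c1)c1ccc(OC)c(O)c1NC(C)=O`) gives 270 nM. Compound 3 thus lies within the usual scatter of compound 1 and clearly on the stronger side of compound 2. Compound 4 (`C=C(c1cc(OC)c(OC)c(OC)c1)c1ccc(OC)c(O)c1NC(=O)CN(C)C`) differs from compound 3 in one place, dimethylamino in place of hydrogen on a saturated chain carbon bound to a carbonyl carbon. Within the data shown here, no measured pair shows this change alone. Compound 2 also carries dimethylamino on such a chain carbon and gives 940 nM, so in this assay a slightly higher number is expected, but no shift beyond the scatter. The expected step is a 1.3-fold higher number from compound 3 to compound 4 (0.11 log units; within the scatter). For compound 4 the estimate is 350 nM, with an expected range of 120 nM to 1000 nM.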

Compound 4, half-maximal inhibitory concentration: 210 nM
For compound 4 the middle estimate is 1.7-fold (0.22 log units) above the measured one; the measured number falls inside the stated range.
By their numbers in this assay, from the lowest: compounds 4, 3 and 1 (each within the scatter of the next); then compound 2.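

In this assay dimethylamino on the saturated chain carbon bound to a carbonyl carbon gives a 1.3-fold lower number from compound 3 to compound 4 (0.11 log units; within the scatter) and so leaves the number within the scatter. Among these compounds, this is the first direct reading of this change alone, and it shows that this position accepts the added group with no clear loss. The data offer no measured explanation for this result. Going by these compounds, whether a piperidine ring, a carboxylic acid or a longer chain would be accepted at this carbon remains open. So does whether the same change would give a similar step on the core of compound 1.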